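This account rests on a few compounds, and the source may have more. Where it says the series, first, only, none or still open, it means among the compounds named here.

These compounds share one core and differ in a single group. In a functional assay on J774 cells (Mus musculus) for cytotoxicity, read by resazurin assay (on this read-out higher numbers stand for weaker inhibition and lower numbers for stronger inhibition), compound 1 `OCCCCCC(O)c1ccc(-c2ccc(F)cc2F)cc1` gives 8000 nM, and compound 3 `Cc1ccc(-c2ccc(C(O)CCCCCO)cc2)cc1` gives 22000 nM, the higher of these two numbers. Compound 2 `Cc1cccc(-c2ccc(C(O)CCCCCO)cc2)c1` gives > 100000 nM, which is a limit of the assay and not a number.

Compound 4 `CCOc1ccc(-c2ccc(C(O)CCCCCO)cc2)cc1` has not yet been measured. It differs from compound 3 by one change, ethoxy in place of methyl on an aromatic carbon, para to a large group: ethoxy in place of methyl on an aromatic carbon.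

Within the data shown here, the one measured step that bears on this change is an at least 4.5-fold lower number from compound 2 to compound 3 (0.65 log units; beyond the scatter), with 4-methylphenyl in place of 3-methylphenyl. That step lies beyond the scatter and shows that the placing of a small group can matter in this assay. Among the measured compounds shown here, compound 4 keeps its new group in the same place as the methyl of compound 3, however, and no measured step replaces one group with another at that carbon. The data therefore offer no clear direction, and the best starting point is the value of compound 3, 22000 nM. The expected step is a 1.1-fold lower number from compound 3 to compound 4 (0.04 log units; within the scatter), which would not go beyond the scatter. For compound 4, the estimated value is 20000 nM, with an expected range of 7000 nM to 60000 nM.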

Compound 4, half-maximal inhibitory concentration: 14000 nM
Beside the measured number, compound 4's estimate is 1.4-fold (0.15 log units) above it, within the range that was stated.
By their numbers in this assay, from the lowest: compounds 1, 4 and 3 (each within the scatter of the next, the first and the last beyond it). At a limit, above all of these: compound 2.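

Among these compounds, until now, the only measured step on this ring moved a methyl group from one place to another; none replaced the group at the carbon para to a large group. Compound 4 supplies that comparison: ethoxy, which is larger than methyl and adds an oxygen and a hydrogen-bond acceptor, replaces methyl at this carbon, giving a 1.6-fold lower number from compound 3 to compound 4 (0.20 log units; within the scatter) in this assay. For this one pair, then, the added atoms and the acceptor leave the numbers within the usual scatter of each other, whereas moving the methyl group from its place in compound 2 to its place in compound 3 gave a step beyond the scatter.

From the compounds shown here alone, it remains open whether an amine, a carboxylic acid or an alkoxy group with a longer chain at this same carbon would also stay within the scatter of compound 3, and whether ethoxy would behave differently at the place held by the methyl group of compound 2. Compound 2 itself gives only a limit and not a number, so the full size of the effect of moving the methyl group stays unknown: the limit of > 100000 nM in this assay, at which 1 of the 4 values shown sits.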